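The source may report more compounds than this note shows. Statements on the series, on what has been measured and on what is new or still open speak of the compounds shown alone.

In an ADME assay on BEAS-2B cells (Homo sapiens) for cytotoxicity, read by MTT assay, with a stated time of 72 h (a higher number here means a weaker inhibitor of growth, a lower number a stronger inhibitor of growth), compound 1 `N#C[Se]c1ccc(NC(=O)Oc2ccc(F)cc2)cc1` gives 45600 nM, compound 2 `N#C[Se]c1ccc(NC(=O)Oc2ccccc2)cc1` gives 38200 nM, and compound 3 `N#C[Se]c1ccc(NC(=O)Oc2ccc(Cl)cc2)cc1` gives 38000 nM. Compound 3 stands within the scatter of both others: the step of a 1.2-fold lower number from compound 1 to compound 3 (0.08 log units; within the scatter), the step of a 1.0-fold lower number from compound 2 to compound 3 (0.00 log units; within the scatter) and the step of a 1.2-fold lower number from compound 1 to compound 2 (0.08 log units; within the scatter) all fall within the usual spread of repeated runs. Compound 4 `COc1ccc(OC(=O)Nc2ccc([Se]C#N)cc2)cc1` differs from compound 3 by methoxy in place of chloro on an aromatic carbon. Each of the three measured steps exchanges a small group on an aromatic carbon of the same ring, and none moved this assay beyond its scatter, so they give no ground to expect a shift in either direction for the methoxy. Compound 4 is expected to give 40000 nM, with a range from 20000 nM to 80000 nM. The step of a 1.1-fold higher number from compound 3 to compound 4 (0.02 log units; within the scatter) is therefore estimated to stay within the scatter.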

Compound 4, concentration for total growth inhibition: 48400 nM
The estimate for compound 4 lay 1.2-fold (0.08 log units) below the measured number; the measured number falls inside the stated range.
By their numbers in this assay, from the lowest: compounds 3, 2, 1 and 4 (each within the scatter of the next).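

In this assay, methoxy brings a hydrogen-bond acceptor to this position, para to a large group, where chloro has none, yet every new step stays within the scatter (a 1.3-fold higher number from compound 3 to compound 4 (0.11 log units; within the scatter)) (a 1.3-fold higher number from compound 2 to compound 4 (0.10 log units; within the scatter)) (a 1.1-fold higher number from compound 1 to compound 4 (0.03 log units; within the scatter)). Hydrogen, fluoro, chloro and methoxy at this position therefore show no step beyond the scatter in this assay. Nothing available explains this result.

The compounds shown leave open whether an amine, a carboxylic acid or a longer alkoxy chain here would stay within the scatter. They also leave open whether a change elsewhere in the shared core would do so.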